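Swapping methyl for phenyl on compound 3

The compounds below may be only part of what the source reports. "The series", "measured", "known", "first", "only" and "open" are said of these compounds alone.

Measured so far in a functional assay on cells (Panel melanoma (Carcinoma cell lines), Homo sapiens) for inhibition; on this read-out lower numbers stand for stronger inhibition of growth and higher numbers for weaker inhibition of growth:
Compound 1 `Cc1ccc(/C=C2\CN(C)CC3=C2N=C(S)NC3c2ccc(C)cc2)cc1` gives > 100000 nM, which is a limit.
Compound 2 `COc1ccc(/C=C2\CN(C)Cc3c2nc(O)c(C#N)c3-c2ccc(OC)cc2)cc1` gives > 100000 nM, which is a limit.
Compound 3 `CN1C/C(=C\c2cccs2)C2=NN(C)C(c3cccs3)C2C1` gives 97700 nM.

Only compound 3, at 97700 nM, has a real number in this small set. The other two readings are limits, so they do not show how far above the measurable range those compounds lie, and they cannot be ranked against compound 3 with any precision.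

The next compound is compound 4 `CN1C/C(=C\c2cccs2)C2=NN(c3ccccc3)C(c3cccs3)C2C1`. It keeps the core of compound 3 and carries phenyl in place of methyl on an amine nitrogen in a ring. That nitrogen sits next to the ring atom that bears a thiophen-2-yl group.

Within the data shown here, no two measured compounds here differ in only one place, so no measured step can serve as a guide. In this assay a modest step toward stronger inhibition is expected, though it may not exceed the usual scatter, and the assay could again report only a limit. The expected change is a 2.2-fold lower number from compound 3 to compound 4 (0.34 log units; beyond the scatter). For compound 4 the estimated value is 45000 nM, with an expected range from 14000 nM to 100000 nM.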

Compound 4, concentration for total growth inhibition: > 100000 nM
Compound 4: only a limit was reported; the forecaster's own chance of this, stated with the estimate: 35%; middle value at least 2.2-fold (0.34 log units) from the limit.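

In this assay, among these compounds, putting phenyl in place of methyl on this amine nitrogen in a ring gives an at least 1.0-fold higher number from compound 3 to compound 4 (0.01 log units; that floor lies within the scatter), the first step in this set that can be read at all. It offers no sign that phenyl here improves inhibition of growth over methyl, although its floor is too small to establish a real loss. Compound 3 already lies close to the top of the measurable range, so the size of any loss stays hidden because the read-out ends at a ceiling: the limit of > 100000 nM in this assay, at which 3 of the 4 values shown sit.

Going by these compounds, it remains open whether any group on this nitrogen can move the number well below that ceiling, for example a hydrogen, an ethyl or a benzyl group, or a phenyl ring that itself carries a methoxy group. On these data alone, it is also open whether phenyl would have the same effect on a compound with much stronger inhibition of growth, where a change in either direction could be measured rather than cut off at the limit.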